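From 4-fluorobenzyl to 2-methylbenzyl on a shared core

The source may hold more compounds than are shown below. What is called first, only, known or untested is meant among the compounds shown, and "the series" means these compounds.

In a functional assay on U-251 cells (Homo sapiens) for antiproliferative activity, read by MTT assay, with a stated time of 24 h (a higher number here means a weaker inhibitor, a lower number a stronger inhibitor), compound 1 `C=CCOc1ccc2c(=O)c(-c3cc(OC)c(OC)cc3OC)coc2c1` gives 5900 nM and compound 2 `COc1cc(OC)c(-c2coc3cc(OCc4ccc(F)cc4)ccc3c2=O)cc1OC` gives 3200 nM, so compound 2 sits level with compound 1 within the scatter. Compound 3 `COc1cc(OC)c(-c2coc3cc(OCc4ccccc4C)ccc3c2=O)cc1OC` keeps the core of compound 2 and has 2-methylphenyl in place of 4-fluorophenyl on a saturated chain carbon bound to an oxygen on an aromatic ring. Among the measured compounds shown here, the only measured change at this place is a 1.8-fold lower number from compound 1 to compound 2 (0.27 log units; within the scatter), so no step beyond the scatter is expected in this assay. The expected step is a 1.1-fold higher number from compound 2 to compound 3 (0.04 log units; within the scatter). The estimate for compound 3 is 3500 nM, with a range of 1400 nM to 8500 nM.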

Compound 3, half-maximal inhibitory concentration: 2000 nM
Beside the measured number, compound 3's estimate is 1.8-fold (0.24 log units) above it; measured number inside the range.
By their numbers in this assay, from the lowest: compounds 3, 2 and 1 (each within the scatter of the next, the first and the last beyond it).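

At this place, on a saturated chain carbon bound to an oxygen on an aromatic ring, this assay does not separate 2-methylphenyl from 4-fluorophenyl: the change gives a 1.6-fold lower number from compound 2 to compound 3 (0.20 log units; within the scatter) and so counts as no real difference. Among the compounds shown here, replacing vinyl with 2-methylphenyl, however, gives a 3.0-fold lower number from compound 1 to compound 3 (0.47 log units; beyond the scatter) as the first step here beyond the scatter, though a modest one. No supporting data explain this step. The compounds shown leave open how an unsubstituted phenyl, or a phenyl carrying an amine or a carboxylic acid, would read at this place.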